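Piperidine to Methylpiperazine on Two Hydroxyphenyl Purine Cores

The source may hold more compounds than are shown below. What is called first, only, known or untested is meant among the compounds shown, and "the series" means these compounds.

The study compares four purine-type compounds in an assay on cells for displacement of a labelled ligand from adenosine receptor A2b (Homo sapiens), read by scintillation counting and radioligand binding, with a stated time of 30 min, tested at 10 uM; a lower number here means less inhibition, a higher number more inhibition at the concentration tested (going by the name of the read-out). Compound 1 `Cn1cnc2c(N3CCCCC3)nc(-c3ccccc3O)nc21` gives 30.2% in this assay, and compound 3 `CN1CCN(c2nc(-c3ccccc3O)nc3c2ncn3C)CC1` gives 36%. The change between them is 4-methylpiperazin-1-yl in place of piperidin-1-yl on an aromatic carbon, and the step it made is a number 5.8 percentage points higher from compound 1 to compound 3 (within the scatter), so the two values lie within the usual scatter of each other.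

Compound 2 `Oc1cccc(-c2nc(N3CCCCC3)c3nc[nH]c3n2)c1` reaches only a limit of this assay, reported as > 80%, which is the limit of > 80% in this assay, at which 1 of the 3 values shown sits. How the core of compound 2 differs from the core of compound 1 is not broken down here.

Compound 4 `CN1CCN(c2nc(-c3cccc(O)c3)nc3[nH]cnc23)CC1` is not yet measured. It differs from compound 2 by 4-methylpiperazin-1-yl in place of piperidin-1-yl on an aromatic carbon. This is the same kind of change as that from compound 1 to compound 3, but the place lines differ: here the site is meta to a 3-hydroxyphenyl group, whereas in compound 1 it is meta to a 2-hydroxyphenyl group.

Because compound 2 sits at > 80% and the earlier step of a number 5.8 percentage points higher from compound 1 to compound 3 (within the scatter) stayed within the scatter, the expected step is a step that the limit leaves unreadable from compound 2 to compound 4. Compound 4 is therefore estimated at 82%, with a range from 62% to 95%.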

Compound 4, a percentage reported as inhibition, at one concentration (the size of the read-out at that concentration, not a potency): 27%
For compound 4 the middle estimate is 55 percentage points above the measured one, outside the stated range (below it).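

On the core of compound 2, 4-methylpiperazin-1-yl in place of piperidin-1-yl gave a number at least 53 percentage points lower from compound 2 to compound 4 (beyond the scatter) in this assay. The change therefore did not carry over with the same result from one core to the other: the same change on two cores in this assay, a number 5.8 percentage points higher (within the scatter) from compound 1 to compound 3 and a number at least 53 percentage points lower (beyond the scatter) from compound 2 to compound 4, at least 58.8 percentage points apart, beyond the scatter of two such steps This does not show which feature of the two cores separates the outcomes, whether the 3-hydroxyphenyl group of compound 2, the 2-hydroxyphenyl group of compound 1 or another difference between them, and the full size of the new step stays unknown, as the value of compound 2 is a limit of the assay and not a number: the limit of > 80% in this assay, at which 1 of the 4 values shown sits.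

The compounds shown leave open how a morpholin-4-yl group or an unsubstituted piperazin-1-yl group would read at the same site on either core. They also leave open whether the second ring nitrogen or the methyl group of 4-methylpiperazin-1-yl goes with the lower reading of compound 4.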